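From 4-Aminophenyl to 3,4-Dichlorophenyl on the Carbonyl

The source may report more compounds than this note shows. Statements on the series, on what has been measured and on what is new or still open speak of the compounds shown alone.

Of the compounds shown here, two have been measured in a functional assay on NCI-H322M cells (Homo sapiens) for inhibition, read by sulforhodamine B assay, with a stated time of 48 h; a higher number here means that more compound is tolerated, a lower number that less compound is tolerated. Compound 1 `COc1cc(-c2cc(/C=C/C(=O)c3ccc(N)cc3)[nH]n2)cc(OC)c1OC` gives 20900 nM in this assay, and compound 2 `COc1ccc(-c2cc(/C=C/C(=O)c3ccc(OC)c(OC)c3)[nH]n2)cc1` gives 18700 nM. Of the two numbers, that of compound 1 is the larger one, yet the two lie within the usual scatter of each other, so nothing separates them.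

Compound 3 `COc1cc(-c2cc(/C=C/C(=O)c3ccc(Cl)c(Cl)c3)[nH]n2)cc(OC)c1OC` has not yet been measured. Relative to compound 1 it carries 3,4-dichlorophenyl in place of 4-aminophenyl on a carbonyl carbon. Among the measured compounds shown here, no pair of measured compounds differing in a single place is available, so the size of this step can only be guessed. A modest move toward a lower number in this assay is expected, at the edge of the scatter. Compound 3 is therefore estimated at 12000 nM in this assay, with a range from 4000 nM to 40000 nM. This expectation corresponds to a step of a 1.7-fold lower number from compound 1 to compound 3 (0.24 log units; within the scatter).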

Compound 3, concentration lethal to 50% of the cells: > 100000 nM
Compound 3 ended at the assay's limit (the forecaster's own chance of this, stated with the estimate: 5%); middle value at least 8.3-fold (0.92 log units) away from the limit.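

Exchanging 4-aminophenyl for 3,4-dichlorophenyl on the carbonyl carbon gives, in this assay, an at least 4.7-fold higher number from compound 1 to compound 3 (0.67 log units; beyond the scatter), the only step shown that can be read, and it lies beyond the scatter, so the group at this position does change the result. For compound 3, the value > 100000 nM is a limit of the assay and not a number. The step is therefore a lower bound, and its full size stays unknown: the limit of > 100000 nM in this assay, at which 1 of the 3 values shown sits.

The change removes the amine and adds both chlorine atoms in a single exchange, so it leaves open which of these carries the step. Plain phenyl or 4-chlorophenyl on the same carbonyl carbon would separate the two, and whether either would also reach the limit remains an open question.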